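The source may hold more compounds than are shown below. What is called first, only, known or untested is meant among the compounds shown, and "the series" means these compounds.

Compound 1 `Cc1c(OCCCCOc2ccc(C(=O)C(C)C)c(O)c2C)cccc1C(=O)O`, compound 2 `CCC(=O)c1ccc(OCCCCOc2cccc(C(=O)O)c2C)c(C)c1O` and compound 3 `Cc1cc(C(=O)O)ccc1OCCCCOc1ccc(C(=O)C(C)C)c(O)c1C` were examined in an assay on HEK293 cells for positive allosteric modulation of metabotropic glutamate receptor 2 (Rattus norvegicus), read by thallium flux, with a stated time of 2.5 min; on this read-out higher numbers stand for larger maximal responses and lower numbers for smaller maximal responses. In this assay compound 1 gives 66.9%, compound 2 gives 71.3% and compound 3 gives 76.9%. Compound 2 differs from compound 1 by a single change, (hydrogen in place of methyl on a saturated chain carbon bound to a carbonyl carbon and a saturated chain carbon), and this change produced a number 4.4 percentage points higher from compound 1 to compound 2 (within the scatter). The core of compound 3 and the core of compound 1 also differ, but that difference is not broken down here. Compound 4 `CCC(=O)c1ccc(OCCCCOc2ccc(C(=O)O)cc2C)c(C)c1O` has not yet been measured in this assay. It differs from compound 3 by the same change, (hydrogen in place of methyl on a saturated chain carbon bound to a carbonyl carbon and a saturated chain carbon), at a place described in the same words. Because the earlier step of a number 4.4 percentage points higher from compound 1 to compound 2 (within the scatter) stayed within the scatter, the new step is expected to be a number 3.1 percentage points higher from compound 3 to compound 4 (within the scatter). Compound 4 is therefore expected to reach 80%, estimated to lie between 68% and 92%.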

Compound 4, largest response reached (reported as percent of maximum), in percent of the reference or control that the assay uses: 86.6%
Beside the measured number, compound 4's estimate is 6.6 percentage points below it; the range from low to high includes it.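

In this assay, the change from isopropylcarbonyl to propanoyl gave a number 9.7 percentage points higher from compound 3 to compound 4 (within the scatter). Set beside the earlier step, the change behaves alike on the two cores: the same change on two cores in this assay, a number 4.4 percentage points higher (within the scatter) from compound 1 to compound 2 and a number 9.7 percentage points higher (within the scatter) from compound 3 to compound 4, 5.3 percentage points apart, within the scatter of two such steps. This suggests that the change carries from one of these cores to the other without a clear difference in its effect, but since each step stays within the scatter, it does not show that the change itself raises the response, and two cores say nothing about any others.

The compounds shown leave open what a longer chain, such as butanoyl, or a ring-bearing group, such as cyclopropylcarbonyl, would do in this place. They also leave open whether an amide could stand in for the carboxylic acid.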